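Swapping the Benzoxazole Arm of Compound 1 for a Smaller Ring

A few compounds are considered here, and "the series" means these few. Any claim that something is new, unique, unknown or untested is made for them only; others in the source may bear on it.

Among the compounds with values here, compound 1 `Cn1c(-c2ccc(NC(=O)CSc3nc4ccccc4o3)cc2)nc(-c2ccccc2)c1-c1ccccc1` is the stronger of the two compounds measured so far. In a functional assay on HT-29 cells (Homo sapiens) for cytotoxicity, read by MTT assay, with a stated time of 24 h, tested at 16 ug/mL (a lower number here means a weaker effect, a higher number a stronger effect of the compound at the concentration tested), compound 1 gives 56.2%, the highest of the two numbers. Within the data shown here, its only measured neighbour is compound 2 `Cc1ccc2oc(SCC(=O)Nc3ccc(-c4nc(-c5ccccc5)c(-c5ccccc5)n4C)cc3)nc2c1`, which in this assay gives 37.7%; the step of a number 18.5 percentage points lower from compound 1 to compound 2 (beyond the scatter) comes from a methyl in place of hydrogen on an aromatic carbon.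

Compound 3 `Cn1c(-c2ccc(NC(=O)CSC3=NCCS3)cc2)nc(-c2ccccc2)c1-c1ccccc1` keeps the shared core and the amide linker of compound 1 but changes the group on the sulfur: a group of 5 heavy atoms (3 carbon, 1 nitrogen, 1 sulfur; one five-membered non-aromatic ring with 2 hetero atoms) in place of a group of 9 heavy atoms (7 carbon, 1 nitrogen, 1 oxygen; one five-membered aromatic ring with 2 hetero atoms, one six-membered aromatic ring of carbon only), on a sulfur

Among the measured compounds shown here, no measured step touches this part of the molecule. For the measured compounds named here, the single step from compound 1 to compound 2 concerns a methyl added on the far benzoxazole ring, a group that compound 3 no longer carries, so it does not bear on this change. With no direct guide, and a large aromatic group replaced by a small non-aromatic one, a loss of activity beyond the scatter is expected, though its size is uncertain. For compound 3 the estimate is 38%, with a range from 18% to 58%, which means an expected step of a number 18.2 percentage points lower from compound 1 to compound 3 (beyond the scatter).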

Compound 3, a percentage reported as activity, at one concentration (the size of the read-out at that concentration, not a potency): 43.3%
Beside the measured number, compound 3's estimate is 5.3 percentage points below it, and the stated range covers the measured number.
By their numbers in this assay, from the lowest: compounds 2 and 3 (each within the scatter of the next); then compound 1.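

The sulfur position does not depend on the full 1,3-benzoxazol-2-yl group: with the much smaller five-membered non-aromatic ring in its place, this assay shows a number 12.9 percentage points lower from compound 1 to compound 3 (beyond the scatter) and a clear effect remains at the concentration tested. The new ring also brings the number level with that of the methyl-bearing benzoxazole, with a number 5.6 percentage points higher from compound 2 to compound 3 (within the scatter) so that compound 2 and compound 3 cannot be told apart here, and the two changes at the far end of compound 1 therefore lower the read-out to a similar level despite being very different in size. No available information explains why either change lowers the number.

This swap alters several things at once, including the size of the group, the number of rings, the ring's aromatic character and a ring oxygen exchanged for a ring sulfur, so the compounds shown cannot say which of these matters. A single aromatic ring such as phenyl or thiazol-2-yl on the same sulfur would help separate these features, while a plain methyl there would show how much of the read-out survives with no ring at all.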